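Bromo for Chloro on a Second Ring

The source may hold more compounds than are shown below. What is called first, only, known or untested is meant among the compounds shown, and "the series" means these compounds.

Measured compounds:
compound 1, `O=C(/C(=C\c1ccc(Br)cc1)SCc1ccc(Cl)cc1)c1ccc(Br)cc1`: 1000 nM
compound 2, `O=C(/C(=C\c1ccc(Cl)cc1)SCc1ccc(Cl)cc1)c1ccc(Br)cc1`: 10000 nM
compound 3, `CSc1ccc(/C=C(/SCc2ccc(C)cc2)C(=O)c2ccc(Cl)cc2)cc1`: 25000 nM

In a functional assay on DU-145 cells (Homo sapiens) for inhibition, read by trypan blue exclusion, with a stated time of 96 h (on this read-out lower numbers stand for stronger inhibition of growth and higher numbers for weaker inhibition of growth), compound 1 gives 1000 nM and compound 2 gives 10000 nM. The two differ by bromo in place of chloro on an aromatic carbon, and this change made a 10-fold lower number from compound 2 to compound 1 (1.00 log units; beyond the scatter). Compound 3 gives 25000 nM; how its core differs from that of compound 2 is not broken down here. Compound 4, `CSc1ccc(/C=C(/SCc2ccc(C)cc2)C(=O)c2ccc(Br)cc2)cc1`, differs from compound 3 by bromo in place of chloro on an aromatic carbon. The place reads the same as before, but one bond further out the change is (4-chlorophenyl)carbonyl to (4-bromophenyl)carbonyl, so it is the same kind of change on a different ring. Because the earlier step was a 10-fold lower number from compound 2 to compound 1 (1.00 log units; beyond the scatter), compound 4 is expected to give a lower number than compound 3, though a smaller step is expected, a 2.5-fold lower number from compound 3 to compound 4 (0.40 log units; beyond the scatter), since the ring differs. The estimate for compound 4 is 10000 nM, between 3000 nM and 30000 nM.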

Compound 4, concentration for 50% growth inhibition: > 100000 nM
Compound 4: no number, only a limit (the forecaster's own chance of this, stated with the estimate: 5%); at least 10-fold (1.00 log units) between middle value and limit.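

In this assay, bromo in place of chloro did not carry over from one core to the other: the same change on two cores in this assay, a 10-fold lower number (1.00 log units; beyond the scatter) from compound 2 to compound 1 and an at least 4.0-fold higher number (0.60 log units; beyond the scatter) from compound 3 to compound 4, at least 40-fold (1.60 log units) apart, beyond the scatter of two such steps

On the core of compound 3 the change gave an at least 4.0-fold higher number from compound 3 to compound 4 (0.60 log units; beyond the scatter), which runs the opposite way to a 10-fold lower number from compound 2 to compound 1 (1.00 log units; beyond the scatter). Going by these compounds, compound 4 gives > 100000 nM, which is a limit and not a number; the full size of its step stays unknown, and nothing here shows which of the differences between the two cores turns the change around.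

The compounds shown leave open how a fluoro or a methoxy group at the same place would read on either core. Also open, on these data alone, is whether the same swap would follow either pattern on a core carrying an amine.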